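Cyanoguanidine series: compound 3 at the limit, compound 4 pending

The source may hold more compounds than are shown below. What is called first, only, known or untested is meant among the compounds shown, and "the series" means these compounds.

Measured so far:
compound 1 `CN/C(=N/C#N)NCCCc1c[nH]c(C)n1` gives < 5
compound 2 `CN/C(=N/C#N)NCCCCc1nc[nH]c1C` gives < 5
compound 3 `N#C/N=C(\NCCCCc1cnn[nH]1)NCCSc1ccccc1` gives < 5

In a functional assay on Sf9 cells for antagonist activity at histamine H2 receptor (Homo sapiens), read by scintillation counting and GTPgammaS binding, with a stated time of 90 min (on this read-out higher numbers stand for higher potency (the scale is a negative logarithm) and lower numbers for lower potency), every value recorded so far is a limit of the assay and not a number. Compound 3 stands at that limit, < 5, together with the rest of the set, as summed up by the limit of < 5 in this assay, at which 3 of the 3 values shown sit. With no measured step between any two of these compounds, no measured step size is available to carry over; the only footing is that the whole set has stayed at the limit.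

Compound 4 `N#C/N=C(\NCCCNc1nc(N)n[nH]1)NCCSc1ccccc1` differs from compound 3 by (3-amino-1H-1,2,4-triazol-5-yl)amino in place of (1H-1,2,3-triazol-5-yl)methyl on a saturated chain carbon, three bonds along the chain from an amine nitrogen. With nothing measured along this change, no direction can be read from the data, and any step from compound 3 to compound 4 is expected to stay within the scatter or, at most, just beyond it toward higher potency. Compound 4 is therefore estimated at 5.2, with a range from 4.4 to 6, which corresponds to an expected step of a number at least 0.20 log units higher from compound 3 to compound 4 (that floor lies within the scatter), and a sizeable chance remains that compound 4 is again reported only as a limit.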

Compound 4, negative logarithm of the antagonist equilibrium constant: < 5
Compound 4 ended at the assay's limit; the forecaster's own chance of this, stated with the estimate: 55%; middle value at least 0.20 log units away from the limit.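

The step between compound 3 and compound 4 cannot be read in this assay, because both values are limits of the assay and not numbers: the limit of < 5 in this assay, at which 4 of the 4 values shown sit.

The compounds shown leave open whether any change in this series yields a numeric potency, and how large any step would be.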